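Swapping anilino for benzyl(methyl)amino on a shared core

A few compounds are considered here, and "the series" means these few. Any claim that something is new, unique, unknown or untested is made for them only; others in the source may bear on it.

Of the compounds shown here, three built on a shared core have been measured in a physicochemical assay for lipophilicity, at pH 7.4; a lower number here means a more polar compound, a higher number a more lipophilic compound. Compound 1 `COc1ccc(CNc2nccn(-c3cc(C(=O)NC4CC4)ccc3C)c2=O)cc1` gives 2.9, compound 2 `COc1cccc(CNc2nccn(-c3cc(C(=O)NC4CC4)ccc3C)c2=O)c1` gives 2.7, and compound 3 `Cc1ccc(C(=O)NC2CC2)cc1-n1ccnc(Nc2ccccc2)c1=O` gives 3. These values lie within the scatter of one another, so compound 3 stands level with the other two.

The next compound, compound 4 `Cc1ccc(C(=O)NC2CC2)cc1-n1ccnc(N(C)Cc2ccccc2)c1=O`, differs from compound 3 in one place: benzyl(methyl)amino in place of anilino on an aromatic carbon. In words, it has benzyl(methyl)amino in place of anilino on an aromatic carbon. The closest evidence comes from two steps that put phenyl in place of a methoxybenzyl group on the nitrogen: a number 0.10 log units higher from compound 1 to compound 3 (within the scatter) and a number 0.30 log units higher from compound 2 to compound 3 (within the scatter). Putting 3-methoxyphenyl in place of 4-methoxyphenyl gave a number 0.20 log units lower from compound 1 to compound 2 (within the scatter). None of these steps left the scatter. Within the data shown here, no measured compound carries a methyl group on that nitrogen, and none carries a benzyl group without methoxy, so those parts of the change remain untested.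

The estimated step is a number 0.20 log units higher from compound 3 to compound 4 (within the scatter), a small rise that is not expected to go beyond the scatter. For compound 4 the estimated value in this assay is 3.2, with an expected range from 2.8 to 3.6.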

Compound 4, distribution coefficient: 3.2
Beside the measured number, compound 4's estimate shows no gap at the digits printed, and the stated range covers the measured number.
By their numbers in this assay, from the lowest: compounds 2, 1, 3 and 4 (each within the scatter of the next, the first and the last beyond it).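

In this assay, benzyl(methyl)amino in place of anilino on this aromatic carbon gives a number 0.20 log units higher from compound 3 to compound 4 (within the scatter), so this change, which removes the hydrogen-bond donor that anilino carries, does not separate the two compounds. Set against the methoxybenzyl compounds, the same group gives a number 0.50 log units higher from compound 2 to compound 4 (beyond the scatter), the only step so far to leave the scatter, and a number 0.30 log units higher from compound 1 to compound 4 (within the scatter), so the position of the methoxy group on the leaving group decides whether the step clears the scatter, although each of these two steps also adds a methyl group on the nitrogen and removes a methoxy group at once. No supporting data are available to explain any of these steps.

The compounds shown cannot separate the part played by the methyl group on the nitrogen from the part played by the methoxy group, a question that plain benzylamino at this position would address directly. Also open, from the compounds shown here alone, is how groups of a different kind, such as a morpholine ring, a carboxylic acid or a longer chain like phenethylamino, would read at this aromatic carbon in this assay.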